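The source may hold more compounds than are shown below. What is called first, only, known or untested is meant among the compounds shown, and "the series" means these compounds.

Measured compounds:
compound 1 `COc1ncc(-c2ccc3nc(NC(=O)NCCN4CCCC4)sc3c2)cc1NS(=O)(=O)c1ccc(F)cc1`, 310 nM
compound 2 `CCN(CC)CCNC(=O)Nc1nc2ccc(-c3cnc(OC)c(NS(=O)(=O)c4ccc(F)cc4)c3)cc2s1`, 300 nM

In a functional assay on HCT-116 cells (Homo sapiens) for antiproliferative activity, read by MTT assay, with a stated time of 72 h (a lower number here means a stronger inhibitor, a higher number a weaker inhibitor), compound 2 gives 300 nM, and compound 1 gives 310 nM, so the two stand within the scatter of each other; the step of a 1.0-fold lower number from compound 1 to compound 2 (0.01 log units; within the scatter) shows as much. Compound 3 `COc1ncc(-c2ccc3nc(NC(=O)NC4CC4)sc3c2)cc1NS(=O)(=O)c1ccc(F)cc1` differs from compound 2 by cyclopropyl in place of 2-(diethylamino)ethyl on an amide-type nitrogen. Within the data shown here, the one measured step swaps only the amine end of that chain and stays within the scatter, so no measured step covers removing the chain altogether. Compound 3 is therefore expected to give 600 nM, with a range of 150 nM to 3000 nM. This estimate means a step of a 2.0-fold higher number from compound 2 to compound 3 (0.30 log units; within the scatter), expected to be somewhat weaker but with wide uncertainty.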

Compound 3, half-maximal inhibitory concentration: 470 nM
Beside the measured number, compound 3's estimate is 1.3-fold (0.11 log units) above it; the range from low to high includes it.
By their numbers in this assay, from the lowest: compounds 2, 1 and 3 (each within the scatter of the next).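

In this assay, putting cyclopropyl on the amide-type nitrogen in place of the whole amine-bearing chain gives a 1.6-fold higher number from compound 2 to compound 3 (0.19 log units; within the scatter) and a 1.5-fold higher number from compound 1 to compound 3 (0.18 log units; within the scatter) so both steps stay within the scatter. The earlier pair exchanged only the amine end of the chain, whereas here the amine and the chain go together and the number still stays within the scatter of both compounds. No evidence on the reason for this accompanies these compounds.

Still open, as far as these compounds go, is whether a longer chain ending in an amine, a chain ending in a carboxylic acid, or a larger ring such as cyclohexyl on that nitrogen would also stay within the scatter.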